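The source may hold more compounds than are shown below. What is called first, only, known or untested is meant among the compounds shown, and "the series" means these compounds.

Compound 1 `O=C1c2ccccc2S(=O)(=O)N1CCCCCCN1CCN(c2ccccc2F)CC1` is the weakest-looking member of a small series built on a shared core linked through a seven-carbon chain to an arylpiperazine. In an ADME assay on HEK293 cells for displacement of a labelled ligand from 5-hydroxytryptamine receptor 7 (Homo sapiens), read by radioligand binding, with a stated time of 1 h (a lower number here means a stronger inhibitor, a higher number a weaker inhibitor), compound 1 gives 322 nM, the highest number of the three measured. Its nearest neighbour is compound 3 `O=C1c2ccccc2S(=O)(=O)N1CCCCCCN1CCN(c2ccccc2)CC1`, which in this assay gives 192 nM; the step of a 1.7-fold lower number from compound 1 to compound 3 (0.22 log units; within the scatter) lies within the scatter, so the two cannot be ranked. For the measured compounds named here, compound 2 `O=C1c2ccccc2S(=O)(=O)N1CCCCCCN1CCN(c2cccc(C(F)(F)F)c2)CC1` gives 58 nM in this assay, and the step of a 5.6-fold lower number from compound 1 to compound 2 (0.74 log units; beyond the scatter) is the only one from compound 1 that goes beyond the scatter. The related step of a 3.3-fold higher number from compound 2 to compound 3 (0.52 log units; beyond the scatter) points the same way.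

Compound 4 `O=C1c2ccccc2S(=O)(=O)N1CCCCCCN1CCN(c2cccc3ccccc23)CC1` differs from compound 1 in one place: naphthalen-1-yl in place of 2-fluorophenyl on an amine nitrogen in a ring. Going by the values given here, of the measured steps, the one from compound 1 to compound 2 bears most on this, since it also exchanges the whole aryl group on the ring nitrogen for another, and it was modest but beyond the scatter toward a lower number. The step from compound 1 to compound 3 adds little, being within the scatter. A modest step toward a lower number is therefore expected for compound 4, about a 5.4-fold lower number from compound 1 to compound 4 (0.73 log units; beyond the scatter). Compound 4 is estimated at 60 nM in this assay, with a range from 15 nM to 250 nM.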

Compound 4, inhibition constant: 20 nM
The estimate for compound 4 lay 3.0-fold (0.48 log units) above the measured number; the measured number falls inside the stated range.
By their numbers in this assay, from the lowest: compound 4; then compound 2; then compounds 3 and 1 (each within the scatter of the next).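

In this assay, for the compounds shown here, the exchange of the aryl group on the amine nitrogen in a ring goes further than the earlier compounds showed: the change to naphthalen-1-yl gives a large step (a 16-fold lower number from compound 1 to compound 4 (1.21 log units; beyond the scatter)), whereas the only earlier step from compound 1 beyond the scatter was modest. The gain is not confined to the comparison with 2-fluorophenyl, since naphthalen-1-yl also gives a modest step from the unsubstituted phenyl (a 9.6-fold lower number from compound 3 to compound 4 (0.98 log units; beyond the scatter)) and a modest step from the 3-(trifluoromethyl)phenyl group (a 2.9-fold lower number from compound 2 to compound 4 (0.46 log units; beyond the scatter)), which makes compound 4 the strongest of the four and shows that, among these compounds, the lowest number belongs to a group of two aromatic rings rather than a substituted phenyl. Nothing at hand accounts for the size of these steps.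

The compounds shown leave open whether the gain is specific to naphthalen-1-yl or would also appear with naphthalen-2-yl, or with a methoxy group on the phenyl ring. They also leave open whether the naphthalen-1-yl gain would hold with a shorter or longer chain between the shared core and the piperazine-type ring.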